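A Heteroaromatic Ring Replaces a Methoxymethyl Group

This account rests on a few compounds, and the source may have more. Where it says the series, first, only, none or still open, it means among the compounds named here.

Three compounds sharing one core are compared in an ADME assay on HEK293 cells (Homo sapiens) for cytotoxicity, read by ATP content, with a stated time of 6 h; a lower number here means that less compound is tolerated, a higher number that more compound is tolerated. Compound 1 `CCCCNc1nc(N)nc2ccn(CC(=O)NC)c12` carries a butylamino group and a methylamide on its side chain. In this assay compound 1 gives > 24000 nM, and this is a limit of the assay rather than a measured number. Compound 2 `COCCNc1nc(N)nc2ccn(Cc3ccccn3)c12` carries a methoxyethylamino group and a pyridylmethyl group. In this assay compound 2 gives > 24000 nM, again a limit and not a number. For the measured compounds named here, compound 2 therefore stands at the limit, and the only other value available sits at that same limit: the limit of > 24000 nM in this assay, at which 2 of the 2 values shown sit.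

Compound 3 `Cc1cc(CNc2nc(N)nc3ccn(Cc4ccccn4)c23)no1` keeps the pyridylmethyl group and changes the side chain: 5-methyl-1,2-oxazol-3-yl in place of methoxymethyl on a saturated chain carbon bound to a nitrogen on an aromatic ring. No measured step of this kind exists among these compounds. Since both measured compounds sit at the limit, the change is expected to yield no shift beyond the usual scatter, and the step that the limit leaves unreadable from compound 2 to compound 3 is an estimate only. For compound 3 the value in this assay is expected to be about 30000 nM, most plausibly between 10000 nM and 90000 nM.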

Compound 3, half-maximal cytotoxic concentration: > 24000 nM
Compound 3 gave a limit, no number; the forecaster's own chance of this, stated with the estimate: 70%; the middle value lies beyond the limit too.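

No step can be read from compound 2 to compound 3, because both compounds sit at a limit and not at a number: the limit of > 24000 nM in this assay, at which 3 of the 3 values shown sit.

The compounds shown leave open at what concentration any of them would harm the cells in this assay and whether 5-methyl-1,2-oxazol-3-yl in place of methoxymethyl changes that concentration at all.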